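Fluoromethyl ketone series: cytotoxicity on Vero cells

The compounds below may be only part of what the source reports. "The series", "measured", "known", "first", "only" and "open" are said of these compounds alone.

Measured compounds and their readings in a functional assay on Vero cells (Chlorocebus sabaeus) for cytotoxicity (a lower number here means that less compound is tolerated, a higher number that more compound is tolerated), each a limit of the assay rather than a number:
- Compound 1 `CCC(C)[C@H](NC(=O)OCc1ccccc1)C(=O)NC(CCC(=O)N(C)C)C(=O)CF` gives > 100000 nM.
- Compound 2 `CC(C)[C@H](NC(=O)OCc1ccccc1)C(=O)NC(CCC(=O)N(C)C)C(=O)CF` gives > 100000 nM.
- Compound 3 `CN(C)C(=O)CCC(NC(=O)CNC(=O)OCc1ccccc1)C(=O)CF` gives > 100000 nM.

All three values sit at the limit, so none of the steps between them can be read. From compound 2 to compound 1 the change is methyl in place of hydrogen on a saturated chain carbon, three bonds along the chain from an amide-type nitrogen and a carbonyl carbon, and the step is a step that the two limits leave unreadable from compound 2 to compound 1. The cores of compound 2 and compound 3 differ by hydrogen in place of isopropyl on a saturated chain carbon bound to an amide-type nitrogen and a carbonyl carbon, with the step that the two limits leave unreadable from compound 2 to compound 3. The remaining pair gives a step that the two limits leave unreadable from compound 1 to compound 3. Going by the values given here, the only evidence in this assay is the limit of > 100000 nM in this assay, at which 3 of the 3 values shown sit.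

Compound 4 `C[C@H](NC(=O)OCc1ccccc1)C(=O)NC(CCC(=O)N(C)C)C(=O)CF` is not yet measured in this assay. It differs from compound 3 by methyl in place of hydrogen on a saturated chain carbon bound to an amide-type nitrogen and a carbonyl carbon. This is the same kind of change as that from compound 2 to compound 1, but the surroundings differ: in compound 2 to compound 1 the methyl enters on a saturated chain carbon three bonds along the chain from an amide-type nitrogen and a carbonyl carbon, whereas in compound 3 to compound 4 it enters on a saturated chain carbon bound to an amide-type nitrogen and a carbonyl carbon.

Expectation: since every measured compound, including compound 3 at > 100000 nM, sits at the limit, the step from compound 3 to compound 4 is estimated as a step that the limit leaves unreadable from compound 3 to compound 4, and compound 4 is expected to come out near 150000 nM, most likely again as a limit, within 70000 nM to 400000 nM.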

Compound 4, half-maximal cytotoxic concentration: > 100000 nM
Compound 4 was reported as a limit; the forecaster's own chance of this, stated with the estimate: 85%; the middle value lies beyond the limit too.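

In this assay compound 4 gives > 100000 nM, which is a limit of the assay. The steps joining compound 4 to compound 1, compound 2 and compound 3 therefore cannot be read: the limit of > 100000 nM in this assay, at which 4 of the 4 values shown sit.

The compounds shown leave open whether hydrogen, methyl, isopropyl or sec-butyl on the saturated chain carbon bound to an amide-type nitrogen and a carbonyl carbon makes any difference to the tolerated concentration.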